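Aziridine Ureas: Removing the Ester of Compound 2

The compounds below may be only part of what the source reports. "The series", "measured", "known", "first", "only" and "open" are said of these compounds alone.

Measured so far:
Compound 1 `CCCCNC(=O)N1CC1C#N` gives 6700 nM in a functional assay on MCF7 cells (Homo sapiens) for inhibition; on this read-out lower numbers stand for stronger inhibition and higher numbers for weaker inhibition.
Compound 2 `CCOC(=O)c1ccc(NC(=O)N2CC2C#N)cc1` gives 2100 nM in this assay .

Of the two numbers in hand, compound 2 stands lowest; compound 1, with a butyl chain on the urea in place of the aryl group, gives a higher number, and that gap lies beyond the scatter of the assay. The shared core of the two compounds, the nitrile-bearing three-membered ring carrying the urea, is unchanged between them, so the whole difference rests on what hangs from the urea nitrogen.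

Compound 3 `N#CC1CN1C(=O)Nc1ccccc1` keeps the aryl urea of compound 2 but differs from it in one place: hydrogen in place of ethoxycarbonyl on an aromatic carbon. Among the measured compounds shown here, no measured pair isolates this change, so nothing in the numbers so far tells how the ester contributes. With the aryl group retained, compound 3 is expected to stay nearer compound 2 than compound 1, but the loss of the ethoxycarbonyl is estimated to weaken inhibition somewhat, a step from compound 2 to compound 3 of a 2.1-fold higher number from compound 2 to compound 3 (0.33 log units; beyond the scatter), beyond the scatter in the direction of a higher number. Compound 3 is therefore estimated at 4500 nM, within a range of 1200 nM to 16000 nM.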

Compound 3, half-maximal inhibitory concentration: 2600 nM
For compound 3 the middle estimate is 1.7-fold (0.24 log units) above the measured one, within the range that was stated.
By their numbers in this assay, from the lowest: compounds 2 and 3 (each within the scatter of the next); then compound 1.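

Putting hydrogen in place of ethoxycarbonyl on this aromatic carbon, para to a group of 8 heavy atoms, amounts in this assay to a 1.2-fold higher number from compound 2 to compound 3 (0.09 log units; within the scatter), so compound 2 and compound 3 cannot be told apart on this read-out. Among the compounds shown here, this pair is the first direct reading of the position, and it shows that the aryl urea keeps its level of inhibition with or without the ester: the ethoxycarbonyl group is not required for the number seen with compound 2, and the position accepts both a group of this size and a bare hydrogen. No information is available that explains why the two compounds read alike.

Only hydrogen and ethoxycarbonyl are shown at this carbon, so it remains open whether an amine, a carboxylic acid or a longer ester chain there would also leave the number in this assay unmoved or would shift it beyond the scatter. Equally open is whether the same holds for such a group on the other carbons of the aromatic ring, since both aryl compounds shown leave those carbons bare.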